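A few compounds are considered here, and "the series" means these few. Any claim that something is new, unique, unknown or untested is made for them only; others in the source may bear on it.

Measured so far in a functional assay on HEK293 cells for antagonist activity at transient receptor potential cation channel subfamily V member 1 (Homo sapiens), read by calcium flux; a lower number here means a stronger inhibitor, a higher number a weaker inhibitor:

Compound 1 `FC(F)(F)c1ccc(Nc2ncnc3sc(Nc4c(Cl)cccc4Cl)nc23)cc1` gives 12 nM.
Compound 2 `FC(F)(F)c1ccc(Nc2nc(N3CCC3)nc3sc(Nc4c(Cl)cccc4Cl)nc23)cc1` gives 59 nM.
Compound 3 `CCN(CC)c1nc(Nc2ccc(C(F)(F)F)cc2)c2nc(Nc3c(Cl)cccc3Cl)sc2n1` gives 48 nM.

Compound 3 stands second highest of the three numbers in this assay. Its nearest neighbour is compound 2, since a 1.2-fold lower number from compound 2 to compound 3 (0.09 log units; within the scatter); its furthest is compound 1, since a 4.0-fold higher number from compound 1 to compound 3 (0.60 log units; beyond the scatter).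

Compound 4 `CC(C)CNc1nc(Nc2ccc(C(F)(F)F)cc2)c2nc(Nc3c(Cl)cccc3Cl)sc2n1` differs from compound 3 in one place: isobutylamino in place of diethylamino on an aromatic carbon. The two measured steps that bear on this position both replaced hydrogen with an amine: a 4.9-fold higher number from compound 1 to compound 2 (0.69 log units; beyond the scatter) and a 4.0-fold higher number from compound 1 to compound 3 (0.60 log units; beyond the scatter). The step between the two amines, a 1.2-fold lower number from compound 2 to compound 3 (0.09 log units; within the scatter), was within the scatter. Both tertiary amines cost a modest amount against compound 1; compound 4 keeps an amine at that carbon, so a number close to that of compound 3 is expected, with a 1.2-fold lower number from compound 3 to compound 4 (0.08 log units; within the scatter) as the expected step, not beyond the scatter. Compound 4 is therefore estimated at 40 nM in this assay, within a range of 12 nM to 130 nM.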

Compound 4, half-maximal inhibitory concentration: 2 nM
Compound 4: middle estimate off by 20-fold (1.30 log units), on the high side; the measured number lies below the stated range.
By their numbers in this assay, from the lowest: compound 4; then compound 1; then compounds 3 and 2 (each within the scatter of the next).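

At the carbon between two ring nitrogen atoms, the identity of the amine matters far more than compound 2 and compound 3 suggested: in this assay, isobutylamino, with one hydrogen-bond donor, in place of donor-free diethylamino gives a 24-fold lower number from compound 3 to compound 4 (1.38 log units; beyond the scatter) and, in place of azetidin-1-yl, gives a 30-fold lower number from compound 2 to compound 4 (1.47 log units; beyond the scatter) at this same carbon. An amine here therefore need not raise the number, since replacing hydrogen with isobutylamino gives a 6.0-fold lower number from compound 1 to compound 4 (0.78 log units; beyond the scatter) while both tertiary amines went the other way. Nothing available explains this difference between the amines.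

The compounds shown cannot separate the amine hydrogen from the branched chain as the feature that matters. N-methyl-isobutylamino would remove that hydrogen while keeping the chain, and n-butylamino would keep the hydrogen while removing the branch.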